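Swapping a Methoxyphenyl for a Trifluoromethylphenyl

This account rests on a few compounds, and the source may have more. Where it says the series, first, only, none or still open, it means among the compounds named here.

Of the compounds shown here, three built on a shared core have been tested so far in a functional assay on EKVX cells (Homo sapiens) for inhibition, read by sulforhodamine B assay, with a stated time of 48 h, tested at 10 uM; a higher number here means more inhibition at the concentration tested (going by the name of the read-out), a lower number less inhibition. Compound 1 `COc1ccc(-c2cn3ccnc3c(-c3ccc4ncn(C5CCCCC5)c4c3)n2)cc1` gives 56.7%. Compound 2 `O=Cc1ccc(-c2cn3ccnc3c(-c3ccc4ncn(C5CCCCC5)c4c3)n2)cc1` gives 20.9%, and compound 3 `COc1ccccc1-c1cn2ccnc2c(-c2ccc3ncn(C4CCCCC4)c3c2)n1` gives 13.4%. Compound 3 thus holds the lowest of the three numbers; compound 2 lies within the scatter of it, while compound 1 stands far higher.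

Compound 4 `FC(F)(F)c1cccc(-c2cn3ccnc3c(-c3ccc4ncn(C5CCCCC5)c4c3)n2)c1` has not yet been measured. It differs from compound 3 in one place: 3-(trifluoromethyl)phenyl in place of 2-methoxyphenyl on an aromatic carbon.

Two of the measured steps are large. The step of a number 43.3 percentage points lower from compound 1 to compound 3 (beyond the scatter) shows a sharp loss when 2-methoxyphenyl replaced 4-methoxyphenyl, and the step of a number 35.8 percentage points lower from compound 1 to compound 2 (beyond the scatter) shows a similar loss when formyl replaced methoxy. The step of a number 7.5 percentage points lower from compound 2 to compound 3 (within the scatter) lay within the scatter. Going by the values given here, none of these steps involves a trifluoromethyl group or a 3-substituted phenyl, so no measured step bears directly on the change to compound 4. Compound 3 sits at the bottom of the range, which leaves room for a rise, and the large drop a number 43.3 percentage points lower from compound 1 to compound 3 (beyond the scatter) came from the very 2-methoxyphenyl that now leaves. A modest recovery is therefore expected, with a wide margin: compound 4 is estimated at 25%, between 5% and 55%, an expected step of a number 11.6 percentage points higher from compound 3 to compound 4 (beyond the scatter).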

Compound 4, a percentage reported as inhibition, at one concentration (the size of the read-out at that concentration, not a potency): 4.79%
Beside the measured number, compound 4's estimate is 20.2 percentage points above it; measured number below the stated range.
By their numbers in this assay, from the lowest: compounds 4, 3 and 2 (each within the scatter of the next, the first and the last beyond it); then compound 1.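

In this assay, replacing the 2-methoxyphenyl with 3-(trifluoromethyl)phenyl brings no recovery: the change gives a number 8.6 percentage points lower from compound 3 to compound 4 (within the scatter), so losing the 2-methoxyphenyl is not enough to raise the number. The new group also falls short of the 4-formylphenyl, with a number 16.1 percentage points lower from compound 2 to compound 4 (beyond the scatter), and much further short of the 4-methoxyphenyl, with a number 51.9 percentage points lower from compound 1 to compound 4 (beyond the scatter), so among these four phenyl groups on this ring carbon, only the 4-methoxyphenyl of compound 1 keeps a sizeable number. Nothing measured here says why the numbers fall this way.

On these data alone, it remains open whether the 4-methoxyphenyl is unusual in holding that number, or whether a 4-hydroxyphenyl, a 4-aminophenyl or the slightly longer 4-ethoxyphenyl would do the same. Also open, as far as these compounds go, is how a 3-methoxyphenyl or a 4-(trifluoromethyl)phenyl would behave, as either one would change only the group or only its place on the phenyl ring, whereas the step to compound 4 changes both at once.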